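The source may hold more compounds than are shown below. What is called first, only, known or untested is meant among the compounds shown, and "the series" means these compounds.

Series notes. Two compounds carry a number in a functional assay on the whole organism (Tail, strain ICR) with Mus musculus as the target, in the tail flick test, with a stated time of 60 min, at a dose of 25 umol/kg by the oral route; on this read-out higher numbers stand for a stronger effect at the one dose given and lower numbers for a weaker effect. Compound 1 `O=C(O)[C@@H]1CCCN1C(=O)CN(c1nc(Cl)nc2[nH]cnc12)C1CC1` gives 34.9% in this assay. Compound 2 `O=C(CN(c1nc(Cl)nc2[nH]cnc12)C1CC1)N[C@@H](CO)C(=O)O` gives 39.8% in this assay. Among the measured compounds shown here, the one measured step in this assay is a number 4.9 percentage points higher from compound 1 to compound 2 (within the scatter), so compound 2 stands within the scatter of compound 1, and neither of the two can be set apart from the other on these numbers.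

Compound 3 `O=C(O)CNC(=O)CN(c1nc(Cl)nc2[nH]cnc12)C1CC1` is not yet measured in this assay. Its difference from compound 2 is hydrogen in place of hydroxymethyl on a saturated chain carbon bound to an amide-type nitrogen and a carbonyl carbon. For the measured compounds named here, no measured step touches the hydroxymethyl; the one step at hand exchanges the whole carboxylic acid part on the carbonyl carbon and stays within the scatter, which gives no hint that the carbonyl-side group moves this assay much. On that basis the step from compound 2 to compound 3 is expected to be a number 2.8 percentage points lower from compound 2 to compound 3 (within the scatter), that is, no change beyond the scatter. Compound 3 is therefore estimated at 37% in this assay, within a range from 20% to 55%.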

Compound 3, a percentage reported as activity, at one dose (the size of the read-out at that dose, not a potency): 38.9%
The estimate for compound 3 lay 1.9 percentage points below the measured number, and the stated range covers the measured number.
By their numbers in this assay, from the lowest: compounds 1, 3 and 2 (each within the scatter of the next).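

In this assay, among the compounds shown here, the first reading at this position, hydrogen in place of hydroxymethyl on a saturated chain carbon bound to an amide-type nitrogen and a carbonyl carbon gives a number 0.9 percentage points lower from compound 2 to compound 3 (within the scatter), so on these numbers compound 2 and compound 3 cannot be told apart, and the hydroxymethyl is not needed to reach the level of compound 2 at this one dose. The exchange on the carbonyl carbon, (carboxymethyl)amino in place of 2-carboxypyrrolidin-1-yl, gives a number 4 percentage points higher from compound 1 to compound 3 (within the scatter), so the simple open chain of compound 3 also cannot be told apart from the ring-bearing compound 1, and the three carbonyl-side groups shown form one level in this assay. No evidence at hand bears on this result.

On these data alone, all three compounds carry a carboxylic acid, so what an ester, a primary amide or an amine in its place would give remains open. As far as these compounds go, a longer chain between the amide-type nitrogen and the carboxylic acid also remains open, as does any change to the shared core.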